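A Benzyl Group Takes the Place of Allyl

A few compounds are considered here, and "the series" means these few. Any claim that something is new, unique, unknown or untested is made for them only; others in the source may bear on it.

In a physicochemical assay for lipophilicity, read by HPLC, measured as octanol-water partition (on this read-out lower numbers stand for lower lipophilicity and higher numbers for higher lipophilicity), compound 1 `COc1ccc(NC(=O)c2cc(-c3sc(NC(=O)C(C)(C)C)nc3C)n(-c3ccc(Br)cc3)n2)cc1` gives 5.52. Among the compounds with values here, compound 2 `C=CCn1nc(C(=O)Nc2ccc(OC)cc2)cc1-c1sc(NC(=O)C(C)(C)C)nc1C` gives 4.75, the lower of the two numbers measured so far. These two compounds differ in one place, with 4-bromophenyl giving way to allyl, and the result is a number 0.77 log units lower from compound 1 to compound 2 (beyond the scatter).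

Compound 3 `COc1ccc(NC(=O)c2cc(-c3sc(NC(=O)C(C)(C)C)nc3C)n(Cc3cc(Cl)ccc3OC)n2)cc1` has not yet been measured. It keeps the rest of compound 2 and changes one group: 5-chloro-2-methoxyphenyl in place of vinyl on a saturated chain carbon bound to an aromatic nitrogen. Put another way, allyl becomes 5-chloro-2-methoxybenzyl, so a six-membered aromatic ring returns to that part of the molecule, as in compound 1.

Within the data shown here, that single measured step is the only guide, so a rise of about the same size is expected. The expected change is a number 0.75 log units higher from compound 2 to compound 3 (beyond the scatter). For compound 3 the estimated value is 5.5, with a range of 5.1 to 5.9.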

Compound 3, partition coefficient: 5.7
For compound 3 the middle estimate is 0.20 log units below the measured one; the measured number falls inside the stated range.
By their numbers in this assay, from the lowest: compound 2; then compounds 1 and 3 (each within the scatter of the next).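

Changing allyl to 5-chloro-2-methoxybenzyl on the aromatic nitrogen gives, in this assay, a number 0.95 log units higher from compound 2 to compound 3 (beyond the scatter), so a high reading at this position does not depend on the six-membered aromatic ring sitting directly on the nitrogen, since here it sits on a saturated chain carbon. Exchanging 4-bromophenyl for 5-chloro-2-methoxybenzyl gives a number 0.18 log units higher from compound 1 to compound 3 (within the scatter), so these two quite different ring-bearing groups cannot be told apart on this read-out. Nothing measured here explains why the numbers behave this way.

From the compounds shown here alone, it remains open what plain benzyl would give, without the chloro and methoxy groups, and so whether those two groups matter or the ring alone accounts for the rise over allyl. Going by these compounds, how a chain ending in an amine or a carboxylic acid would read at this position is also open.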